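The compounds below may be only part of what the source reports. "The series", "measured", "known", "first", "only" and "open" are said of these compounds alone.

Of the compounds shown here, three built on one shared core have been tested in an assay on isolated protein for inhibition of thyroid hormone receptor alpha (Homo sapiens), read by fluorescence polarization; on this read-out higher numbers stand for weaker inhibition and lower numbers for stronger inhibition. Compound 1 `CN(CC(=O)N1CCN(c2ccc(F)cc2)CC1)C(=O)c1ccc(S(C)(=O)=O)c([N+](=O)[O-])c1` gives > 60000 nM in this assay, which is a limit of the measurement and not a number. Compound 2 `CS(=O)(=O)c1ccc(C(=O)N2CCC(C(=O)N3CCc4ccccc4C3)CC2)cc1[N+](=O)[O-]` gives > 60000 nM in this assay, again only a limit. Compound 3 `CS(=O)(=O)c1ccc(C(=O)NCCC(=O)N2CCc3ccccc3C2)cc1[N+](=O)[O-]` gives > 60000 nM in this assay, once more a limit. Within the data shown here, compound 2 therefore stands nowhere apart from its two companions: all three rest at the limit of > 60000 nM in this assay, at which 3 of the 3 values shown sit, and no step between measured compounds can be drawn from these results.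

Compound 4 `CN(Cc1ccccc1F)C(=O)C1CCN(C(=O)c2ccc(S(C)(=O)=O)c([N+](=O)[O-])c2)CC1` has not yet been measured in this assay. It differs from compound 2 in one place: (2-fluorobenzyl)(methyl)amino in place of 1,2,3,4-tetrahydroisoquinolin-2-yl on a carbonyl carbon. Since every measured value sits at the limit of > 60000 nM in this assay, at which 3 of the 3 values shown sit, there is no basis for expecting the change to move the number beyond the usual scatter. The step of a number no higher from compound 2 to compound 4 (the limit leaves the size open) is accordingly expected to be none beyond the scatter. Compound 4 is estimated at 60000 nM in this assay, within a range from 15000 nM to 200000 nM, and most probably reported only as a limit once more.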

Compound 4, half-maximal inhibitory concentration: > 60000 nM
Compound 4: only a limit was reported; the forecaster's own chance of this, stated with the estimate: 80%; the middle value sits exactly at the limit.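

Compound 4, like compound 2, is reported in this assay only as a limit, so no step can be read from compound 2 to compound 4: the limit of > 60000 nM in this assay, at which 4 of the 4 values shown sit.

The compounds shown leave open how these four compounds rank against one another and which change to the shared core, if any, would yield a readable value.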